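Chloro for methoxy on the core: compound 3 to compound 4

The compounds below may be only part of what the source reports. "The series", "measured", "known", "first", "only" and "open" are said of these compounds alone.

Three compounds of the series have numbers in an assay on isolated protein for displacement of a labelled ligand from metabotropic glutamate receptor 5 (Homo sapiens), with a stated time of 60 min, tested at 1 uM; on this read-out higher numbers stand for more inhibition at the one concentration tested (going by the name of the read-out) and lower numbers for less inhibition. Compound 1 `CC1CCN(c2c(S(=O)(=O)c3ccc(F)cc3)cnc3ccc(Cl)cc23)CC1` gives 89% in this assay. For the measured compounds named here, compound 2 `Cc1ccc(S(=O)(=O)c2cnc3ccc(Cl)cc3c2N2CCC(C)CC2)cc1` gives 95%, and the single change from compound 1 amounts to a number 6 percentage points higher from compound 1 to compound 2 (within the scatter). Compound 3 `COc1ccc2ncc(S(=O)(=O)c3cc(C)cc(C)c3)c(N3CCC(C)CC3)c2c1` gives 79%; its number lies below that of compound 2 by a gap beyond the scatter, while against compound 1 the two values sit within the scatter of one another.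

Compound 4 `Cc1cc(C)cc(S(=O)(=O)c2cnc3ccc(Cl)cc3c2N2CCC(C)CC2)c1` arises from compound 3 by one change: chloro in place of methoxy on an aromatic carbon. Going by the values given here, no measured step covers this change. Among the compounds with values here, the only measured step, methyl in place of fluoro on the aryl sulfone, stays within the scatter and tells nothing about the core substituent. What the numbers do show is that both compounds carrying chloro on the core, compound 1 and compound 2, sit higher than compound 3 with methoxy, though only the gap to compound 2 is beyond the scatter.

Compound 4 is therefore expected at 88%, with a range from 76% to 97%, because compound 2 with the same chloro core gives 95%. The expected step of a number 9 percentage points higher from compound 3 to compound 4 (within the scatter) is upward and of a size at the edge of the scatter.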

Compound 4, a percentage reported as inhibition, at one concentration (the size of the read-out at that concentration, not a potency): 49%
Beside the measured number, compound 4's estimate is 39 percentage points above it; the whole stated range lies above it.
By their numbers in this assay, from the lowest: compound 4; then compounds 3, 1 and 2 (each within the scatter of the next, the first and the last beyond it).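

Working from this assay, chloro in place of methoxy on the aromatic carbon of the core gives a number 30 percentage points lower from compound 3 to compound 4 (beyond the scatter), so with 3,5-dimethylphenyl on the sulfonyl sulfur, methoxy carries the higher number of the two groups at this position. With chloro held on the core, the group on the sulfonyl sulfur also counts: 3,5-dimethylphenyl in place of 4-methylphenyl gives a number 46 percentage points lower from compound 2 to compound 4 (beyond the scatter), and 3,5-dimethylphenyl in place of 4-fluorophenyl gives a number 40 percentage points lower from compound 1 to compound 4 (beyond the scatter), whereas the earlier exchange on that aryl ring stayed small, with a number 6 percentage points higher from compound 1 to compound 2 (within the scatter). Chloro on the core therefore does not go with a high number by itself: compounds 1 and 2 fit that reading, and compound 4 goes against it.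

Nothing available bears on the origin of these steps. Still open, from the compounds shown here alone, are whether methoxy keeps its lead over chloro with 4-methylphenyl or 4-fluorophenyl on the sulfonyl sulfur, and how a nitrile, an amine or a longer alkoxy chain at this core position would compare with methoxy and chloro.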